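The source may hold more compounds than are shown below. What is called first, only, known or untested is meant among the compounds shown, and "the series" means these compounds.

Within the data shown here, compound 1 `O=C(Nc1ccc(Cl)c(-c2nnc3c(Cl)cccn23)c1)c1ccc(C(F)(F)F)cc1F` is the only member of this small set with an actual number in a functional assay on T47D cells (Homo sapiens) for antiproliferative activity, read by MTT assay, with a stated time of 72 h (a lower number here means a stronger inhibitor, a higher number a weaker inhibitor), where compound 1 gives 70800 nM. Compound 2 `Cc1cc(Cl)ccc1C(=O)Nc1ccc(Cl)c(-c2nnc3c(Cl)cccn23)c1` reaches only a limit of the assay in this assay, reported as > 100000 nM rather than a number. Compound 3 `O=C(Nc1ccc(Cl)c(-c2nnc3c(Cl)cccn23)c1)c1ccon1` likewise stands at a limit in this assay, reported as > 100000 nM. Among the measured compounds shown here, the one change between measured neighbours, a step that the two limits leave unreadable from compound 2 to compound 3, therefore cannot be read, and the lone position of compound 1 rests on (the limit of > 100000 nM in this assay, at which 2 of the 3 values shown sit). Compound 4 `O=C(Nc1ccc(Cl)c(-c2nnc3c(Cl)cccn23)c1)c1ccc(C(F)(F)F)cc1Cl` differs from compound 1 by chloro in place of fluoro on an aromatic carbon. For the measured compounds named here, no measured step involves this exchange of chloro for fluoro, and the single step that does exist tells nothing of its size, so there is no measured basis for expecting movement in either direction. The step of a 1.0-fold lower number from compound 1 to compound 4 (0.00 log units; within the scatter) is expected to stay within the scatter. In this assay compound 4 is estimated at 70000 nM, with a range from 25000 nM to 200000 nM.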

Compound 4, half-maximal inhibitory concentration: > 100000 nM
Compound 4: no number, only a limit; the forecaster's own chance of this, stated with the estimate: 35%; middle value at least 1.4-fold (0.15 log units) away from the limit.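

In this assay, among these compounds, the aromatic carbon ortho to a large group and meta to a trifluoromethyl group gives the first single exchange with a readable direction, an at least 1.4-fold higher number from compound 1 to compound 4 (0.14 log units; that floor lies within the scatter). The floor of that step lies within the scatter, so chloro in place of fluoro is not shown to weaken the compound by more than repeated measurements would vary. Among the compounds shown here, compound 4 stands at a limit of the assay rather than a number, which leaves compound 1 as the only compound here with a measured value: the limit of > 100000 nM in this assay, at which 3 of the 4 values shown sit.

On these data alone, how far compound 4 lies past its limit stays open, so the true size of this step is unknown. Also open, as far as these compounds go, is how a methoxy group or an amine at this position would compare with fluoro in compound 1.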